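Replacing methyl with (pent-4-yn-1-yl)oxy on a carbonyl carbon

A few compounds are considered here, and "the series" means these few. Any claim that something is new, unique, unknown or untested is made for them only; others in the source may bear on it.

In a functional assay on Hs 683 cells (Homo sapiens) for inhibition, read by MTT assay, with a stated time of 72 h (a higher number here means a weaker inhibitor of growth, a lower number a stronger inhibitor of growth), compound 1 (`COC(=O)/C=C/C1=CC[C@H]2C(C)(C)CCC[C@]2(C)[C@H]1C=O`) gives 24000 nM and compound 2 (`CC(=O)/C=C/C1=CC[C@H]2C(C)(C)CCC[C@]2(C)[C@H]1C=O`) gives 22000 nM, two numbers within the scatter of each other. Compound 3 (`C#CCCCOC(=O)/C=C/C1=CC[C@H]2C(C)(C)CCC[C@]2(C)[C@H]1C=O`) differs from compound 2 by (pent-4-yn-1-yl)oxy in place of methyl on a carbonyl carbon. Among the compounds with values here, the one measured step, a 1.1-fold lower number from compound 1 to compound 2 (0.04 log units; within the scatter), exchanged methoxy and methyl on a carbonyl carbon. Within the data shown here, no measured compound shows what the (pent-4-yn-1-yl)oxy group does, so this is only a weak guide and the range stays wide. The estimated 1.1-fold lower number from compound 2 to compound 3 (0.04 log units; within the scatter) lies within the scatter in this assay. For compound 3 the expected value is 20000 nM, with an estimated range from 8000 nM to 45000 nM.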

Compound 3, concentration for 50% growth inhibition: 33000 nM
Compound 3: the middle estimate sits 1.7-fold (0.22 log units) below what was measured; the range from low to high includes it.
By their numbers in this assay, from the lowest: compounds 2, 1 and 3 (each within the scatter of the next).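

In this assay, two steps, a 1.5-fold higher number from compound 2 to compound 3 (0.18 log units; within the scatter) and a 1.4-fold higher number from compound 1 to compound 3 (0.14 log units; within the scatter), both lie within the scatter. So this carbonyl carbon accepts not only methyl and methoxy but also the much larger (pent-4-yn-1-yl)oxy group, with its triple bond, without a readable shift in growth inhibition. No supporting data bear on why this is so.

Still open, on these data alone, is whether any group here can move the number beyond the scatter. An amine or a carboxylic acid at this carbonyl carbon, or a much longer chain, could test that.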